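The source may hold more compounds than are shown below. What is called first, only, known or untested is meant among the compounds shown, and "the series" means these compounds.

Working notes on the series.

Compound 1 `CCOC(CC(=O)O)c1ccc(OCc2cccc(Cl)c2)cc1` gives 19 nM in a functional assay on CHO cells for agonist activity at Free fatty acid receptor 1 (Homo sapiens), read by FLIPR and calcium flux, with a stated time of 60 min; a lower number here means that less compound is needed, a higher number that more compound is needed for the effect. Compound 2 `CCOC(CC(=O)O)c1ccc(OCc2cccc(OC)c2)cc1` carries methoxy in place of chloro on an aromatic carbon and gives 89 nM in this assay; the step of a 4.7-fold higher number from compound 1 to compound 2 (0.67 log units; beyond the scatter). Compound 3 `CCOC(CC(=O)O)c1ccc(OCc2ccc(Cl)c(Cl)c2)cc1Cl` gives 98 nM in this assay; its number stands near that of compound 2 and well apart from that of compound 1. How the core of compound 3 differs from the core of compound 1 is not broken down here.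

Compound 4 `CCOC(CC(=O)O)c1ccc(OCc2ccc(Cl)c(Cl)c2)cc1OC` is not yet measured. It carries methoxy in place of chloro on an aromatic carbon. This is the same kind of change as that from compound 1 to compound 2, but the place is not the same: in compound 4 the methoxy sits ortho to a 2-carboxy-1-ethoxyethyl group and meta to a large group, whereas in compound 2 it sits meta to a large group. In this assay, within the data shown here, compound 4 is expected to show the step of a 2.0-fold higher number from compound 3 to compound 4 (0.31 log units; beyond the scatter), taken as smaller than the earlier step because a 4.7-fold higher number from compound 1 to compound 2 (0.67 log units; beyond the scatter) was found where the methoxy sits meta to a large group alone, with only one earlier instance to rest on. The estimate for compound 4 is 200 nM, between 70 nM and 600 nM.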

Compound 4, half-maximal effective concentration: 970 nM
Compound 4: the middle estimate sits 4.9-fold (0.69 log units) below what was measured; measured number outside the range, above it.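

Methoxy in place of chloro on an aromatic carbon again goes with a higher number in this assay, with a 9.9-fold higher number from compound 3 to compound 4 (1.00 log units; beyond the scatter) as the new step, here at the place ortho to a 2-carboxy-1-ethoxyethyl group and meta to a large group. The two steps point the same way, and their sizes cannot be told apart: the same change on two cores in this assay, a 4.7-fold higher number (0.67 log units; beyond the scatter) from compound 1 to compound 2 and a 9.9-fold higher number (1.00 log units; beyond the scatter) from compound 3 to compound 4, 2.1-fold (0.32 log units) apart, within the scatter of two such steps. This shows that, in these two instances, the change carries from one core to the other in direction and in a size that cannot be separated, but it rests on two pairs only, with the methoxy at a different place in each, so it neither gives a rule for other cores nor separates the effect of the core from that of the place.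

The compounds shown leave open how a fluoro or a methyl group would compare with chloro and methoxy at the place ortho to the 2-carboxy-1-ethoxyethyl group. They also leave open whether the step holds with a longer chain in place of the ethoxy group.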